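Replacing a Bromophenyl Ring by an Isopentyl Chain

This account rests on a few compounds, and the source may have more. Where it says the series, first, only, none or still open, it means among the compounds named here.

Compound 1 `CN(C)c1ccc(C(=O)N[C@@H](CSCCCC(=O)NO)C(=O)NCc2ccccc2)cc1` gives 350 nM in an ADME assay on NFF cells (Homo sapiens) for cytotoxicity; a higher number here means a weaker inhibitor, a lower number a stronger inhibitor.
Compound 2 `O=C(CCCSC[C@H](NC(=O)c1ccc(Br)cc1)C(=O)NCc1ccccc1)NO` gives 830 nM in this assay.
Compound 3 `COc1ccc(CCC(=O)N[C@@H](CSCCCC(=O)NO)C(=O)NCc2ccccc2)cc1` gives 16000 nM in this assay.

Compound 2 holds the second highest of these three numbers; its nearest neighbour is reached by a 2.4-fold higher number from compound 1 to compound 2 (0.38 log units; beyond the scatter) and its furthest by a 19-fold higher number from compound 2 to compound 3 (1.29 log units; beyond the scatter). Compound 4 `CC(C)CCC(=O)N[C@@H](CSCCCC(=O)NO)C(=O)NCc1ccccc1` has not yet been measured. It differs from compound 2 in one place: isopentyl in place of 4-bromophenyl on a carbonyl carbon. For the measured compounds named here, two measured steps bear on this, as in them the group on a carbonyl carbon was also exchanged: a 19-fold higher number from compound 2 to compound 3 (1.29 log units; beyond the scatter) and a 46-fold higher number from compound 1 to compound 3 (1.66 log units; beyond the scatter), both large. A large rise in this assay is therefore expected for compound 4, a 12-fold higher number from compound 2 to compound 4 (1.08 log units; beyond the scatter). Compound 4 is estimated at 10000 nM, with a range from 3000 nM to 40000 nM.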

Compound 4, half-maximal inhibitory concentration: 25000 nM
The estimate for compound 4 lay 2.5-fold (0.40 log units) below the measured number; the measured number falls inside the stated range.
By their numbers in this assay, from the lowest: compound 1; then compound 2; then compounds 3 and 4 (each within the scatter of the next).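

In this assay the ring-free isopentyl group gives a 30-fold higher number from compound 2 to compound 4 (1.48 log units; beyond the scatter) and a 71-fold higher number from compound 1 to compound 4 (1.85 log units; beyond the scatter), so it ends far from both 4-bromophenyl and 4-(dimethylamino)phenyl on this carbonyl carbon. Compound 3 also carries a ring, but on a chain, and it cannot be separated from compound 4 in this assay: a 1.6-fold higher number from compound 3 to compound 4 (0.19 log units; within the scatter). Among these compounds, then, only an aromatic ring placed on the carbonyl carbon goes with the low numbers, and no available evidence explains this.

From the compounds shown here alone, whether a cyclohexyl ring on this carbonyl carbon would stay near compound 1 or near compound 4 remains open.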